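The source may report more compounds than this note shows. Statements on the series, on what has been measured and on what is new or still open speak of the compounds shown alone.

Measured in a functional assay on MCF7 cells (Homo sapiens) for inhibition, read by CCK-8 assay, with a stated time of 72 h; a lower number here means a stronger inhibitor, a higher number a weaker inhibitor:
- compound 1 `Cc1ccc(NS(=O)(=O)c2cccc(CCCCCCNC(=O)/C=C/c3cccnc3)c2)cc1`: 1.97 nM
- compound 2 `Cc1ccc(C)c(NS(=O)(=O)c2cccc(CCCCCCNC(=O)/C=C/c3cccnc3)c2)c1`: 0.6 nM

Compound 2 holds the lower of the two numbers in this assay, at 0.6 nM. The next compound is compound 3 `CCc1ccc(NS(=O)(=O)c2cccc(CCCCCCNC(=O)/C=C/c3cccnc3)c2)cc1`, with 4-ethylphenyl in place of 2,5-dimethylphenyl on a sulfonamide nitrogen.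

Going by the values given here, one measured step bears on this change. It is a 3.3-fold lower number from compound 1 to compound 2 (0.52 log units; beyond the scatter), with 2,5-dimethylphenyl in place of 4-methylphenyl on a sulfonamide nitrogen. The change to 4-ethylphenyl leaves 2,5-dimethylphenyl again, and its group differs from the 4-methylphenyl of compound 1 (1.97 nM) by name as ethyl for methyl. A step of similar modest size is therefore expected, towards a higher number, though this rests on a single pair. The expected step is a 3.3-fold higher number from compound 2 to compound 3 (0.52 log units; beyond the scatter). For compound 3 the estimated value is 2 nM, with an expected range of 0.7 nM to 6 nM.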

Compound 3, half-maximal inhibitory concentration: 3.64 nM
Beside the measured number, compound 3's estimate is 1.8-fold (0.26 log units) below it; measured number inside the range.
By their numbers in this assay, from the lowest: compound 2; then compounds 1 and 3 (each within the scatter of the next).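

In this assay the move from 2,5-dimethylphenyl to 4-ethylphenyl on the sulfonamide nitrogen gives a 6.1-fold higher number from compound 2 to compound 3 (0.78 log units; beyond the scatter) and so undoes the gain seen earlier, although the two groups have the same atoms, joined differently. Ethyl in place of methyl on the single-substituted ring gives a 1.8-fold higher number from compound 1 to compound 3 (0.27 log units; within the scatter) and so does not separate 4-ethylphenyl from 4-methylphenyl. Within these three compounds, 2,5-dimethylphenyl alone stands apart from the other two groups, as both of its steps lie beyond the scatter. Nothing at hand accounts for these differences.

As far as these compounds go, it stays open whether an unsubstituted phenyl or a ring with only one of the two methyl groups would match compound 2 at 0.6 nM in this assay. Chloro or methoxy in place of those methyl groups is equally open.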